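The source may hold more compounds than are shown below. What is called first, only, known or untested is meant among the compounds shown, and "the series" means these compounds.

Working notes on the series. Compound 1 `CC(C)(C)OC(=O)NCCOc1cc(NC(=O)c2cnccn2)c2ncccc2c1` is the reference point; in a functional assay on MIA PaCa-2 cells (Homo sapiens) for inhibition, read by MTT assay, with a stated time of 72 h (a lower number here means a stronger inhibitor, a higher number a weaker inhibitor), compound 1 gives 870 nM. Compound 2 `NCCOc1cc(NC(=O)c2cnccn2)c2ncccc2c1` carries the change hydrogen in place of tert-butoxycarbonyl on an amine nitrogen relative to compound 1. In this assay compound 2 reaches only a limit of the assay, > 10000 nM. From the compounds shown here alone, the step of an at least 11-fold higher number from compound 1 to compound 2 (1.06 log units; beyond the scatter) is thus capped by the limit of > 10000 nM in this assay, at which 2 of the 3 values shown sit, and its full size remains unknown. Compound 3 `CC(C)(C)OC(=O)NCCOc1cc(NC(=O)c2ncccn2)c2ncccc2c1` keeps the tert-butoxycarbonyl of compound 1 but differs in the core (pyrimidin-2-yl in place of pyrazin-2-yl on a carbonyl carbon). In this assay compound 3 likewise sits at a limit of the assay, > 10000 nM. The step of an at least 11-fold higher number from compound 1 to compound 3 (1.06 log units; beyond the scatter) is bounded by the limit of > 10000 nM in this assay, at which 2 of the 3 values shown sit, in the same way.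

Compound 4 `NCCOc1cc(NC(=O)c2ncccn2)c2ncccc2c1` has not yet been measured in this assay. It differs from compound 3 by hydrogen in place of tert-butoxycarbonyl on an amine nitrogen, which is the same change as that from compound 1 to compound 2, made at the same place on the same kind of nitrogen. That change, applied to a measured starting point, produced the large step of an at least 11-fold higher number from compound 1 to compound 2 (1.06 log units; beyond the scatter). Compound 3 starts at the limit (the limit of > 10000 nM in this assay, at which 2 of the 3 values shown sit), so any further weakening can only move the value deeper beyond what the assay reports. The expected step that the limit leaves unreadable from compound 3 to compound 4 therefore rests on an at least 11-fold higher number from compound 1 to compound 2 (1.06 log units; beyond the scatter) but is not expected to be readable as a number. Compound 4 is expected at about 30000 nM, within 10000 nM to 150000 nM, and is expected to be reported as a limit of the assay.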

Compound 4, half-maximal inhibitory concentration: > 10000 nM
Compound 4: a limit, no number; the forecaster's own chance of this, stated with the estimate: 90%; the middle value is on the limit's open side.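

For the compounds shown here, compound 4 gives no new readable step against compound 3 or compound 2, since all three compounds stand only as limits in this assay: the limit of > 10000 nM in this assay, at which 3 of the 4 values shown sit. The compounds shown leave open how far compound 2, compound 3 and compound 4 lie past that limit, and whether hydrogen in place of tert-butoxycarbonyl changes anything once pyrimidin-2-yl stands in place of pyrazin-2-yl.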